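The compounds below may be only part of what the source reports. "The series", "measured", "known", "first", "only" and "open" are said of these compounds alone.

Compound 1 `O=C(Nc1ccccc1)Nc1ccc(Oc2ccc(-c3nccs3)cc2)cc1` is a diaryl urea in which one phenyl ring carries an ether link to a second ring that bears a thiazole. For compound 1 the result in a functional assay on MDA-MB-231 cells (Homo sapiens) for inhibition, read by MTT assay and WST assay, with a stated time of 72 h, tested at 10 uM (on this read-out lower numbers stand for less inhibition of growth and higher numbers for more inhibition of growth at the one concentration tested), is "not determined" (no result reported), so it cannot be placed on the numbers at all. What is known comes from two relatives that keep the thiazole and vary the other end of the urea. Compound 2 `O=C(Nc1ccc(Oc2ccc(-c3nccs3)cc2)cc1)Nc1cc(C(F)(F)F)ccc1Cl` gives 60.4% in this assay, and compound 3 `O=C(Nc1ccc(Oc2ccc(-c3nccs3)cc2)cc1)Nc1ccc(F)c(Cl)c1` gives 43.9%. Among the compounds with values here, the single measured step, a number 16.5 percentage points lower from compound 2 to compound 3 (beyond the scatter), lies entirely on the nitrogen-bound phenyl ring and leaves the thiazole untouched.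

The change from compound 1 to compound 4 `O=C(Nc1ccccc1)Nc1ccc(Oc2ccc(-c3ncc[nH]3)cc2)cc1` is a different one: 1H-imidazol-2-yl in place of 1,3-thiazol-2-yl on an aromatic carbon. Within the data shown here, no measured step touches this ring, so nothing in the data speaks to its size or direction. The two measured values only show the band in which compounds of this urea series fall at the concentration tested. Among the measured compounds shown here, compound 4 is therefore expected to land somewhere in that band, and its value in this assay is estimated at 45%, within a range from 15% to 70%, with the wide span reflecting that no relevant step is known.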

Compound 4, percent growth inhibition at one concentration: 11.4%
Compound 4: the middle estimate sits 33.6 percentage points above what was measured; measured number below the stated range.
By their numbers in this assay, from the lowest: compound 4; then compound 3; then compound 2.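

No new step can be read for compound 4: compound 1 offers no number to set beside it, and compound 2 and compound 3 differ from compound 4 in more than one place. Nothing at hand explains the value of compound 4. The compounds shown leave open how 1H-imidazol-2-yl compares with 1,3-thiazol-2-yl on the same core.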